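A few compounds are considered here, and "the series" means these few. Any claim that something is new, unique, unknown or untested is made for them only; others in the source may bear on it.

In a functional assay on MCF7 cells (Homo sapiens) for antiproliferative activity, read by sulforhodamine B assay, with a stated time of 48 h (a higher number here means a weaker inhibitor, a lower number a stronger inhibitor), compound 3 `CCCN1CCN(c2ccc(S(=O)(=O)Oc3c(Cl)cc(Cl)cc3Cl)cc2)C1=O` gives > 100000 nM, which is a limit of the assay and not a number. Compound 1 `CN1CCN(c2ccc(S(=O)(=O)Oc3c(Cl)cc(Cl)cc3Cl)cc2)C1=O` gives 2900 nM and compound 2 `CCCN1CCN(c2ccc(S(=O)(=O)Oc3ccccc3OC)cc2)C1=O` gives 13000 nM. Compound 4 `CCCN1CCN(c2ccc(S(=O)(=O)Oc3cccc([N+](=O)[O-])c3)cc2)C1=O` carries the change (3-nitrophenyl in place of 2,4,6-trichlorophenyl on an oxygen), with 3-nitrophenyl in place of 2,4,6-trichlorophenyl on an oxygen bound to the sulfonyl sulfur.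

The measured step at this same place is an at least 7.6-fold higher number from compound 2 to compound 3 (0.88 log units; beyond the scatter), at least modest in size, with 2,4,6-trichlorophenyl in place of 2-methoxyphenyl. The other measured step, an at least 34-fold higher number from compound 1 to compound 3 (1.53 log units; beyond the scatter), is large but lies on the chain at the amide-type nitrogen, so it bears less directly. Compound 4 keeps the chain of compound 3 and loses the 2,4,6-trichlorophenyl, so a step of at least modest size towards a lower number is expected in this assay, landing near compound 2 at 13000 nM. This expectation rests on a single step at this oxygen. The expected change is an at least 6.6-fold lower number from compound 3 to compound 4 (0.82 log units; beyond the scatter). For compound 4 the estimate is 15000 nM, with an expected range of 4000 nM to 60000 nM.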

Compound 4, half-maximal inhibitory concentration: 19000 nM
Compound 4: the middle estimate sits 1.3-fold (0.10 log units) below what was measured, within the range that was stated.
By their numbers in this assay, from the lowest: compound 1; then compounds 2 and 4 (each within the scatter of the next). At a limit, above all of these: compound 3.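

With the chain of compound 3 kept, a second replacement on the oxygen bound to the sulfonyl sulfur also gives a measurable value in this assay: 3-nitrophenyl in place of 2,4,6-trichlorophenyl gives an at least 5.2-fold lower number from compound 3 to compound 4 (0.72 log units; beyond the scatter). The value of compound 3 is a limit and not a number: the limit of > 100000 nM in this assay, at which 1 of the 4 values shown sits. The 3-nitrophenyl and 2-methoxyphenyl groups are not separated on this chain, with a 1.5-fold higher number from compound 2 to compound 4 (0.16 log units; within the scatter), so among the three groups carried on it, only 2,4,6-trichlorophenyl stands apart.

Going by these compounds, how 3-nitrophenyl would read on the chain of compound 1 stays open, as does what an amine or a carboxylic acid on the aromatic ring at this oxygen would give. The compounds shown also give no cause for the separation of 2,4,6-trichlorophenyl on this chain.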